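Swapping a trifluoromethyl benzyl for a methyl benzyl

This account rests on a few compounds, and the source may have more. Where it says the series, first, only, none or still open, it means among the compounds named here.

Of the compounds shown here, three built on one shared core have been tested in a functional assay on HeLa cells (Homo sapiens) for cytotoxicity, read by MTT assay, with a stated time of 72 h; a higher number here means a weaker inhibitor, a lower number a stronger inhibitor. Compound 1 `Cc1cc(-c2ccccc2)n(/C(N)=N/S(=O)(=O)c2cc(C)c(Cl)cc2SCc2cccc3ccccc23)n1` carries a naphthalen-1-yl group on a saturated chain carbon bound to a sulfur and gives 3000 nM. Compound 2 `Cc1ccc(CSc2cc(Cl)c(C)cc2S(=O)(=O)/N=C(\N)n2nc(C)cc2-c2ccccc2)cc1` carries a 4-methylphenyl at that place and gives 62000 nM. Compound 3 `Cc1cc(-c2ccccc2)n(/C(N)=N/S(=O)(=O)c2cc(C)c(Cl)cc2SCc2ccc(C(F)(F)F)cc2)n1` carries a 4-(trifluoromethyl)phenyl there and gives 19000 nM, which puts it second highest of the three numbers, with compound 2 nearest and compound 1 furthest. The measured steps are a 21-fold higher number from compound 1 to compound 2 (1.32 log units; beyond the scatter), a 6.3-fold higher number from compound 1 to compound 3 (0.80 log units; beyond the scatter) and a 3.3-fold lower number from compound 2 to compound 3 (0.51 log units; beyond the scatter).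

Compound 4 `Cc1cccc(CSc2cc(Cl)c(C)cc2S(=O)(=O)/N=C(\N)n2nc(C)cc2-c2ccccc2)c1` has not yet been measured. The change from compound 3 is 3-methylphenyl in place of 4-(trifluoromethyl)phenyl on a saturated chain carbon bound to a sulfur. For the measured compounds named here, the step that bears most directly on it is a 3.3-fold lower number from compound 2 to compound 3 (0.51 log units; beyond the scatter): compound 4, like compound 2, carries a methyl rather than a trifluoromethyl, although the methyl now stands as 3-methylphenyl rather than 4-methylphenyl, and no measured compound shows that exact arrangement. Reversing that step suggests a modest rise in the number, meaning a weaker inhibitor, landing somewhere between compound 3 and compound 2. The expected step is a 2.1-fold higher number from compound 3 to compound 4 (0.32 log units; beyond the scatter). Compound 4 is therefore estimated at 40000 nM, with a range from 15000 nM to 100000 nM.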

Compound 4, half-maximal inhibitory concentration: 155000 nM
Estimate against measurement, compound 4: 3.9-fold (0.59 log units) below; the whole stated range lies below it.
By their numbers in this assay, from the lowest: compound 1; then compound 3; then compound 2; then compound 4.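

For the compounds shown here, the position on the ring matters here, not only which group is present: in this assay, moving the methyl from 4-methylphenyl to 3-methylphenyl gives a 2.5-fold higher number from compound 2 to compound 4 (0.40 log units; beyond the scatter) and so changes the result beyond the usual scatter, something the earlier compounds could not show. The new group also does worse against the other two groups at this place on a saturated chain carbon bound to a sulfur, with an 8.2-fold higher number from compound 3 to compound 4 (0.91 log units; beyond the scatter) against 4-(trifluoromethyl)phenyl and a 52-fold higher number from compound 1 to compound 4 (1.71 log units; beyond the scatter) against naphthalen-1-yl, which makes compound 4 the weakest of the four in this assay. Nothing measured on these compounds explains why the place of a single methyl should count here.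

Going by these compounds, it remains open whether 3-(trifluoromethyl)phenyl would also give a higher number than 4-(trifluoromethyl)phenyl, which would show whether this preference extends beyond methyl. Also open, on these data alone, is how an unsubstituted phenyl, or a phenyl ring carrying an amine or a carboxylic acid, would compare with the methyl and trifluoromethyl versions at this place.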